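Bromochlorothiophene for bromophenyl on the sulfonyl sulfur

The source may hold more compounds than are shown below. What is called first, only, known or untested is meant among the compounds shown, and "the series" means these compounds.

Measured in a functional assay on HEK293 cells (Homo sapiens) for cytotoxicity; on this read-out lower numbers stand for higher toxicity in this test and higher numbers for lower toxicity in this test:
- compound 1 `COc1ccc([C@H]2CC(=O)N(c3cccc(NCCCc4ccccc4)c3)C2)cc1OC1CCCC1`: > 10000 nM, a limit
- compound 2 `COc1ccc([C@H]2CC(=O)N(c3cccc(NS(=O)(=O)c4cccc(Br)c4)c3)C2)cc1OC1CCCC1`: > 10000 nM, a limit

Compound 2 stands only at a limit. Compound 3 `COc1ccc([C@H]2CC(=O)N(c3cccc(NS(=O)(=O)c4cc(Br)c(Cl)s4)c3)C2)cc1OC1CCCC1` carries 4-bromo-5-chlorothiophen-2-yl in place of 3-bromophenyl on a sulfonyl sulfur. Among the measured compounds shown here, the one measured step, a step that the two limits leave unreadable from compound 1 to compound 2, changes the group on the same nitrogen, and its size cannot be read. Both values sit at one limit: the limit of > 10000 nM in this assay, at which 2 of the 2 values shown sit. The expected step in this assay is a number no higher from compound 2 to compound 3 (the limit leaves the size open), with no change beyond the scatter expected in either direction. This expectation rests on compound 2 at > 10000 nM, a limit. The estimate for compound 3 is 10000 nM, with an expected range from 5000 nM to 20000 nM.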

Compound 3, half-maximal cytotoxic concentration: > 10000 nM
Compound 3 was reported as a limit; the forecaster's own chance of this, stated with the estimate: 75%; the middle value lies on the limit itself.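

No step among compound 1, compound 2 and compound 3 can be read in this assay, since each is reported only as a limit: the limit of > 10000 nM in this assay, at which 3 of the 3 values shown sit.

The compounds shown leave open what actual cytotoxic concentration any of the three has.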